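This account rests on a few compounds, and the source may have more. Where it says the series, first, only, none or still open, it means among the compounds named here.

Two members of the series carry a measured maximal response, and both rest on the same core.

Compound 1, `Cc1c(OCCCCOc2ccc(C(=O)O)c(Cl)c2)ccc(C(=O)CC2CCCC2)c1O`, carries a cyclopentylmethyl ketone and a chloro-substituted benzoic acid; in an assay on HEK293 cells for positive allosteric modulation of metabotropic glutamate receptor 3 (Rattus norvegicus), read by thallium flux, with a stated time of 2.5 min (on this read-out lower numbers stand for smaller maximal responses and higher numbers for larger maximal responses), compound 1 reaches 40%. Compound 2, `Cc1c(OCCCCOc2ccc(F)c(C(=O)O)c2)ccc(C(=O)C(C)C)c1O`, carries an isopropyl ketone and a fluoro-substituted benzoic acid; in this assay compound 2 reaches 31.3%. On the two numbers at hand compound 2 has the lower one, but the gap to compound 1 lies within the usual scatter, so the two values are not distinguishable. Compound 1 and compound 2 differ in two places, so no single step can be read between them.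

Compound 3, `Cc1c(OCCCCOc2ccc(F)c(C(=O)O)c2)ccc(C(=O)CC2CCCC2)c1O`, is the next member. Relative to compound 2 the change is cyclopentylmethyl in place of isopropyl on a carbonyl carbon; the rest of the molecule, including the fluoro-substituted benzoic acid, stays the same.

Among the measured compounds shown here, no step of this kind has been measured. For the measured compounds named here, the only guidance is that compound 1, which already carries the cyclopentylmethyl ketone, reaches 40% in this assay, a number within the scatter of compound 2. The expected step in this assay is therefore small, at most a slight rise, and a number 5.7 percentage points higher from compound 2 to compound 3 (within the scatter) is the estimated change. For compound 3 the expected maximal response in this assay is 37%, with a range from 25% to 50%.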

Compound 3, largest response reached (reported as percent of maximum), in percent of the reference or control that the assay uses: 98.4%
Compound 3: middle estimate off by 61.4 percentage points, on the low side, and the stated range ends below it.
By their numbers in this assay, from the lowest: compounds 2 and 1 (each within the scatter of the next); then compound 3.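

Among the compounds shown here, on the carbonyl carbon, cyclopentylmethyl in place of isopropyl, with the 3-carboxy-4-fluorophenyl group held fixed, gives a number 67.1 percentage points higher from compound 2 to compound 3 (beyond the scatter) in this assay and is the first reading of a single change at this position, which turns out to be highly sensitive to the group it carries. The cyclopentylmethyl ketone does not secure this response on its own: with it held fixed, 3-carboxy-4-fluorophenyl in place of 4-carboxy-3-chlorophenyl on an oxygen on a saturated carbon gives a number 58.4 percentage points higher from compound 1 to compound 3 (beyond the scatter), so among these compounds the high number appears only where the two groups occur together. Nothing at hand accounts for either step.

On these data alone, it remains open whether the gain at the carbonyl carbon needs the five-membered ring or would also appear with an open chain such as n-pentyl or with a cyclohexylmethyl group. Also open, as far as these compounds go, is how the isopropyl ketone behaves with the 4-carboxy-3-chlorophenyl group, and whether a 3-carboxy-4-chlorophenyl group would hold the response of compound 3.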